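The source may hold more compounds than are shown below. What is called first, only, known or untested is meant among the compounds shown, and "the series" means these compounds.

Measured compounds:
Compound 1 `Cc1ncnc2c1c(I)cn2[C@@H]1O[C@H](CO)[C@@H](O)[C@H]1O` in an ADME assay on BJ cells (Homo sapiens), read by MTT assay, with a stated time of 72 h (a higher number here means a weaker inhibitor, a lower number a stronger inhibitor), gives > 100000 nM, which is a limit of the assay and not a number.
Compound 2 `Cc1nc(N)c2c(-c3ccccc3)cn([C@@H]3O[C@H](CO)[C@@H](O)[C@H]3O)c2n1` in this assay gives > 100000 nM, again a limit of the assay rather than a number.

Among the measured compounds shown here, compound 1 therefore stands nowhere in particular on a scale of numbers: it sits at the limit of > 100000 nM in this assay, at which 2 of the 2 values shown sit, and the only other compound shown sits at the same limit, so no ordering between compound 1 and compound 2 can be drawn. For the measured compounds named here, no two measured compounds differ in only one place, and so no measured step is available to set a scale for what a single change can do here.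

Compound 3 `Cc1ncnc2c1c(-c1ccoc1)cn2[C@@H]1O[C@H](CO)[C@@H](O)[C@H]1O` differs from compound 1 by furan-3-yl in place of iodo on an aromatic carbon. Compound 2, which also carries an aromatic ring on the shared core, stays at the limit, and compound 1 with its iodo stays at the limit too. On this footing the step of a number no higher from compound 1 to compound 3 (the limit leaves the size open) is expected to be none beyond the scatter, and compound 3 is estimated to remain at the limit in this assay. The expected value for compound 3 is 100000 nM, with a range from 30000 nM to 300000 nM.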

Compound 3, half-maximal inhibitory concentration: 89200 nM
Beside the measured number, compound 3's estimate is 1.1-fold (0.05 log units) above it; measured number inside the range.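

Among the compounds shown here, with furan-3-yl in place of iodo on this aromatic carbon, this assay returns a number rather than a limit for the first time, as compound 3 gives 89200 nM. The change reads as an at least 1.1-fold lower number from compound 1 to compound 3 (0.04 log units; that floor lies within the scatter), so the measurement fixes only a floor that lies within the scatter, and the true size of the step could be anything from that floor upward. What is new is therefore limited: this place on the shared core can carry a five-membered aromatic ring with the value falling within the measurable range, but the data do not show that the furan-3-yl group gives a real gain over iodo.

The compounds shown leave most of the scale unread, with only a single number so far and the other values still at a limit: the limit of > 100000 nM in this assay, at which 2 of the 3 values shown sit. From the compounds shown here alone, it remains open whether an amine, a carboxylic acid or a longer alkyl chain on this aromatic carbon would give a clearly lower number in this assay or would leave the value at the limit.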